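The source may report more compounds than this note shows. Statements on the series, on what has been measured and on what is new or still open speak of the compounds shown alone.

Measured compounds in the series:

compound 1 `CCCCCC(CCO)n1cnc2c(N(C)C)ncnc21` — in a functional assay on HCT-116 cells (Homo sapiens) for antiproliferative activity, read by MTT assay, with a stated time of 48 h (a higher number here means a weaker inhibitor, a lower number a stronger inhibitor), compound 1 gives > 50000 nM, which is a limit of the assay and not a number.
compound 2 `CCCCCC(CCO)n1cnc2c(N)ncnc21` — compound 2 gives > 50000 nM, again a limit of the assay.
compound 3 `CCCCCCC(CCO)n1cnc2c(N(C)C)ncnc21` — compound 3 gives > 50000 nM, likewise a limit of the assay.

For the measured compounds named here, all three values sit at the same limit, as noted under (the limit of > 50000 nM in this assay, at which 3 of the 3 values shown sit), so none of the measured pairs can be ordered against each other.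

The change from compound 1 to compound 2 is amino in place of dimethylamino on an aromatic carbon. The step it made, a step that the two limits leave unreadable from compound 1 to compound 2, cannot be read, since both ends are limits. The core of compound 3 differs from the core of compound 1 by methyl in place of hydrogen on a saturated chain carbon, six bonds along the chain from an aromatic nitrogen, and that step, a step that the two limits leave unreadable from compound 1 to compound 3, is unreadable for the same reason.

Compound 4 `CCCCCCC(CCO)n1cnc2c(N)ncnc21` has not been measured. It stands to compound 3 as compound 2 stands to compound 1: the change is amino in place of dimethylamino on an aromatic carbon, and the place matches word for word, so it is the same change made on the core of compound 3.

Three limits at one value give no direction for this change. The step from compound 3 to compound 4 in this assay is therefore expected to be a number no higher from compound 3 to compound 4 (the limit leaves the size open), beside the earlier step that the two limits leave unreadable from compound 1 to compound 2, resting on the limit of > 50000 nM in this assay, at which 3 of the 3 values shown sit, and on the value of compound 3, > 50000 nM. The most likely outcome is that compound 4 also returns only a limit. For compound 4 the expected value is 50000 nM, with an estimated range from 25000 nM to 100000 nM.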

Compound 4, half-maximal inhibitory concentration: > 50000 nM
Compound 4 was reported as a limit; the forecaster's own chance of this, stated with the estimate: 90%; the middle value lies on the limit itself.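

In this assay compound 4 gives > 50000 nM as a limit of the assay and not a number. No new step can be read for compound 4 against compound 2 or compound 3, because all the values share one limit: the limit of > 50000 nM in this assay, at which 4 of the 4 values shown sit.

On these data alone, whether amino in place of dimethylamino or the added chain methyl changes antiproliferative activity at all remains open for these four compounds.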